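Methyl for methoxy on the sulfonyl aryl ring

A few compounds are considered here, and "the series" means these few. Any claim that something is new, unique, unknown or untested is made for them only; others in the source may bear on it.

For the measured compounds named here, compound 3 `COc1ccc(S(=O)(=O)/C=C/C(=O)Nc2ccc(Oc3ccnc4cc(OCCCN5CCN(C)CC5)c(OC)cc34)c(F)c2)cc1` is one of three compounds measured in a functional assay on A549 cells (Homo sapiens) for cytotoxicity, read by MTT assay, with a stated time of 72 h; on this read-out lower numbers stand for stronger inhibition and higher numbers for weaker inhibition. In this assay compound 3 gives 1870 nM, which places it second highest of the three numbers. Compound 1 `COc1cc2c(Oc3ccc(NC(=O)c4cn(-c5ccc(Cl)cc5)cn4)cc3F)ccnc2cc1OCCCN1CCN(C)CC1` gives 5200 nM, and compound 2 `COc1cc2c(Oc3ccc(NC(=O)/C=C/S(=O)(=O)c4ccccc4F)cc3F)ccnc2cc1OCCCN1CCN(C)CC1` gives 150 nM. Two single-point steps connect these compounds: a 35-fold lower number from compound 1 to compound 2 (1.54 log units; beyond the scatter), and a 12-fold higher number from compound 2 to compound 3 (1.10 log units; beyond the scatter).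

Compound 4 `COc1cc2c(Oc3ccc(NC(=O)/C=C/S(=O)(=O)c4ccc(C)cc4)cc3F)ccnc2cc1OCCCN1CCN(C)CC1` is the next compound to be measured. It differs from compound 3 by methyl in place of methoxy on an aromatic carbon. Neither measured step covers this change directly. The step from compound 1 to compound 2 exchanges the whole acyl portion and says nothing about the substituent on the sulfonyl aryl ring. The step from compound 2 to compound 3 alters both the identity of that substituent and where it sits on the ring, so it cannot be separated into a substituent effect alone. What the two measured steps do show is that changes around the sulfonyl aryl ring can move the read-out well beyond the scatter. Going by the values given here, with no closely matching precedent, a modest step is expected, with the direction uncertain and a slight lean toward a lower number. Compound 4 is therefore estimated at 1200 nM, with a range from 300 nM to 5000 nM. This corresponds to an expected step of a 1.6-fold lower number from compound 3 to compound 4 (0.19 log units; within the scatter).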

Compound 4, half-maximal inhibitory concentration: 1510 nM
Compound 4: middle estimate off by 1.3-fold (0.10 log units), on the low side, within the range that was stated.
By their numbers in this assay, from the lowest: compound 2; then compounds 4 and 3 (each within the scatter of the next); then compound 1.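

In this assay, replacing the methoxy of the 4-methoxyphenyl group with methyl gives a 1.2-fold lower number from compound 3 to compound 4 (0.09 log units; within the scatter), so at this aromatic carbon, para to a large group, the two substituents cannot be told apart, a substituent change that the earlier step, which also moved the substituent around the ring, could not isolate. For the compounds shown here, the 4-methylphenyl group also places the earlier steps in context: the read-out shows a 10-fold higher number from compound 2 to compound 4 (1.00 log units; beyond the scatter), which, alongside a 12-fold higher number from compound 2 to compound 3 (1.10 log units; beyond the scatter), sets the 2-fluorophenyl group of compound 2 apart from both 4-substituted rings, while a 3.4-fold lower number from compound 1 to compound 4 (0.54 log units; beyond the scatter) shows that a lower number than that of compound 1 does not depend on the 2-fluorophenyl group. Nothing given here accounts for any of these steps.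

Going by these compounds, how an amine, a carboxylic acid or a fluorine on that same aromatic carbon would read remains open, so the flat result rests on methoxy and methyl alone. Also open, on these data alone, is whether the lower number of compound 2 goes with the fluorine itself or with where it sits on the ring.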